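A few compounds are considered here, and "the series" means these few. Any claim that something is new, unique, unknown or untested is made for them only; others in the source may bear on it.

Compound 1 `CN(C(=O)N1CC[C@H](n2cnc3cc(-c4ccc(Cl)cc4)sc3c2=O)C1)[C@H]1CCNC1`: 17 nM
Compound 2 `CN(C(=O)N1CC[C@H](n2cnc3cc(-c4ccc(Cl)cc4)sc3c2=O)C1)[C@H]1CCN(C2CCC(C)(C)CC2)C1`: 2 nM
Compound 3 `CN(C(=O)N1CC[C@H](n2cnc3cc(-c4ccc(Cl)cc4)sc3c2=O)C1)[C@H]1CCN(CC2CC2)C1`: 3 nM

In an assay on isolated protein for binding affinity to melanin-concentrating hormone receptor 1 (Homo sapiens) (a higher number here means a weaker inhibitor, a lower number a stronger inhibitor), compound 3 stands second highest of the three numbers. Its nearest neighbour is compound 2, with a 1.5-fold higher number from compound 2 to compound 3 (0.18 log units; within the scatter); its furthest is compound 1, with a 5.7-fold lower number from compound 1 to compound 3 (0.75 log units; beyond the scatter). Compound 4 `CN(C(=O)N1CC[C@H](n2cnc3cc(-c4ccc(Cl)cc4)sc3c2=O)C1)[C@H]1CCN(CC2CCOC2)C1` differs from compound 3 in one place: oxolan-3-yl in place of cyclopropyl on a saturated chain carbon bound to an amine nitrogen in a ring. Within the data shown here, two measured steps bear on this. Replacing hydrogen on the ring amine nitrogen gave an 8.5-fold lower number from compound 1 to compound 2 (0.93 log units; beyond the scatter) and a 5.7-fold lower number from compound 1 to compound 3 (0.75 log units; beyond the scatter), while exchanging one such group for another gave only a 1.5-fold higher number from compound 2 to compound 3 (0.18 log units; within the scatter), within the scatter. Compound 4 keeps a group on that nitrogen, so the expected step is a 1.2-fold higher number from compound 3 to compound 4 (0.07 log units; within the scatter), none beyond the scatter. Compound 4 is estimated at 3.5 nM, between 1.5 nM and 8 nM.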

Compound 4, inhibition constant: 4 nM
Estimate against measurement, compound 4: 1.1-fold (0.06 log units) below; the measured number falls inside the stated range.
By their numbers in this assay, from the lowest: compounds 2, 3 and 4 (each within the scatter of the next); then compound 1.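

In this assay, oxolan-3-yl, which brings an oxygen and a hydrogen-bond acceptor that cyclopropyl lacks, is accepted at this place: a 1.3-fold higher number from compound 3 to compound 4 (0.12 log units; within the scatter) and a 2.0-fold higher number from compound 2 to compound 4 (0.30 log units; within the scatter) both stay within the scatter. The advantage over hydrogen on the ring amine nitrogen also holds, with a 4.3-fold lower number from compound 1 to compound 4 (0.63 log units; beyond the scatter). No measurement here explains why the oxygen makes so little difference. The compounds shown leave open whether a carboxylic acid or a primary amine on this chain would be accepted as well.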